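A few compounds are considered here, and "the series" means these few. Any claim that something is new, unique, unknown or untested is made for them only; others in the source may bear on it.

Two compounds carrying a shared core, a thiazolidinone joined to a piperidine-bearing chain, have been tested in an ADME assay on Vero cells (Chlorocebus sabaeus) for cytotoxicity, read by neutral red uptake, tested at 787 ug/mL; a higher number here means a weaker effect of the compound at the concentration tested, a lower number a stronger effect. Compound 1, `O=C1CSC(c2cccc(O)c2)N1CCN1CCCCC1`, gives 60% and stands lowest of the two numbers, meaning the stronger effect of the pair. Compound 2, `O=C1CSC(c2ccccc2[N+](=O)[O-])N1CCN1CCCCC1`, gives 100%, a higher number, and the gap between the two lies beyond the scatter. Compound 3, `O=C1CSC(c2cccc(F)c2)N1CCN1CCCCC1`, has not yet been measured. It differs from compound 1 by fluoro in place of hydroxy on an aromatic carbon. Among the measured compounds shown here, with no comparable step measured, the expected change from compound 1 to compound 3 in this assay is a number 10 percentage points higher from compound 1 to compound 3 (within the scatter), a small rise that may stay within the scatter. Compound 3 is therefore estimated at 70%, within a range from 45% to 95%.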

Compound 3, a percentage reported as activity, at one concentration (the size of the read-out at that concentration, not a potency): 27%
The estimate for compound 3 lay 43 percentage points above the measured number; the whole stated range lies above it.
By their numbers in this assay, from the lowest: compound 3; then compound 1; then compound 2.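

In this assay fluoro in place of hydroxy on this aromatic carbon gives a number 33 percentage points lower from compound 1 to compound 3 (beyond the scatter) and so a stronger effect at the concentration tested. Exchanging this one heavy atom, on a carbon meta to a large group, is therefore enough to move the read-out clearly. No measurement here accounts for the shift. As far as these compounds go, what an amine or a methoxy group would do on this same carbon stays open. So does whether fluoro in place of hydroxy would give a similar step elsewhere on the ring.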